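Swapping chloro for methoxy on the shared core

A few compounds are considered here, and "the series" means these few. Any claim that something is new, unique, unknown or untested is made for them only; others in the source may bear on it.

Measured compounds and their values:
- compound 1, `COc1ccc(S(=O)(=O)c2cnc3ccc(OC)cc3c2N2CCC(C)CC2)cc1`: 41%
- compound 2, `COc1ccc2ncc(S(=O)(=O)c3ccc(Cl)c(Cl)c3)c(N3CCC(C)CC3)c2c1`: 87%
- compound 3, `CC1CCN(c2c(S(=O)(=O)c3ccc(F)cc3)cnc3ccc(Cl)cc23)CC1`: 89%

All three were tested in an assay on isolated protein for displacement of a labelled ligand from metabotropic glutamate receptor 5 (Homo sapiens), with a stated time of 60 min, tested at 1 uM; on this read-out higher numbers stand for more inhibition at the one concentration tested (going by the name of the read-out) and lower numbers for less inhibition. Compound 3 sits at the upper end of the numbers shown, with compound 2 so close that the two cannot be told apart, while compound 1 lies far below both.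

Compound 4, `COc1ccc2ncc(S(=O)(=O)c3ccc(F)cc3)c(N3CCC(C)CC3)c2c1`, is not yet measured. It differs from compound 3 in one place: methoxy in place of chloro on an aromatic carbon. For the measured compounds named here, the only measured step, a number 46 percentage points higher from compound 1 to compound 2 (beyond the scatter), changes the ring on the sulfonyl sulfur, not the shared core, so it does not bear directly on this change. What compound 1 and compound 2 do show is that a core carrying methoxy can reach either a low or a high number depending on the sulfonyl ring. Compound 4 carries the 4-fluorophenyl of compound 3 together with the methoxy of compound 2, and its number is therefore expected to stay fairly high, with a modest downward step a number 17 percentage points lower from compound 3 to compound 4 (beyond the scatter) allowed for the uncertainty. The estimate for compound 4 is 72%, within a range from 48% to 92%.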

Compound 4, a percentage reported as inhibition, at one concentration (the size of the read-out at that concentration, not a potency): 27%
Compound 4: the middle estimate sits 45 percentage points above what was measured; the measured number lies below the stated range.
By their numbers in this assay, from the lowest: compound 4; then compound 1; then compounds 2 and 3 (each within the scatter of the next).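

In this assay, this aromatic carbon of the shared core turns out to be highly sensitive when the sulfonyl sulfur carries 4-fluorophenyl: methoxy in place of chloro gives a number 62 percentage points lower from compound 3 to compound 4 (beyond the scatter) in a single change. The methoxy core itself does not fix the outcome, since replacing 3,4-dichlorophenyl with 4-fluorophenyl on the sulfonyl sulfur gives a number 60 percentage points lower from compound 2 to compound 4 (beyond the scatter), while fluoro in place of methoxy on that same ring gives only a number 14 percentage points lower from compound 1 to compound 4 (beyond the scatter), so on this core the chlorines of compound 2 stand out against both smaller ring patterns. Nothing available explains why the steps have these sizes.

From the compounds shown here alone, it remains open whether chloro and methoxy at this carbon would differ as sharply with 3,4-dichlorophenyl or 4-methoxyphenyl on the sulfonyl sulfur, which would show whether the large step belongs to this position alone or to its pairing with 4-fluorophenyl. Also open, going by these compounds, is how an amine, a hydroxyl group or a longer chain such as ethoxy would behave on this carbon of the shared core.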